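A few compounds are considered here, and "the series" means these few. Any claim that something is new, unique, unknown or untested is made for them only; others in the source may bear on it.

In a toxicity assay on microsomes from liver (Homo sapiens) for metabolic stability, read by LC-MS, using NADPH, tested at 1 uM (on this read-out lower numbers stand for slow clearance and higher numbers for fast clearance), compound 1 `CCOc1ncc(-c2nc(C(F)(F)F)sc2N2CCN(C(=O)Cn3nc(C)nc3C)[C@H](C)C2)cn1` gives < 10 mL.min-1.g-1, which is a limit of the assay and not a number. Compound 2 `CCOc1ncc(-c2nc(C(F)(F)F)sc2N2CCN(C(=O)Cn3cnc(C(F)(F)F)n3)[C@H](C)C2)cn1` gives < 10 mL.min-1.g-1, also a limit. The evidence so far is thin: the limit of < 10 mL.min-1.g-1 in this assay, at which 2 of the 2 values shown sit. Going by the values given here, the only measured step is a step that the two limits leave unreadable from compound 1 to compound 2, with 3-(trifluoromethyl)-1H-1,2,4-triazol-1-yl in place of 3,5-dimethyl-1H-1,2,4-triazol-1-yl. Compound 3 `Cc1nc(C)n(CC(=O)N2CCN(c3sc(C(F)(F)F)nc3-c3cnc(C(C)(C)C)nc3)C[C@H]2C)n1` differs from compound 1 elsewhere, by tert-butyl in place of ethoxy on an aromatic carbon, so that 2-ethoxypyrimidin-5-yl becomes 2-(tert-butyl)pyrimidin-5-yl. Among the compounds with values here, no measured step covers this change, and its size stays open. The expectation therefore has only one anchor, the limit of compound 1 at < 10 mL.min-1.g-1. The estimated step is an at least 1.2-fold higher number from compound 1 to compound 3 (0.07 log units; that floor lies within the scatter), a modest one expected toward faster clearance in this assay. For compound 3 the estimate is 12 mL.min-1.g-1, with an expected range of 5 mL.min-1.g-1 to 30 mL.min-1.g-1.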

Compound 3, intrinsic clearance in microsomes: 449 mL.min-1.g-1
Compound 3: the middle estimate sits 37-fold (1.57 log units) below what was measured; measured number outside the range, above it.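

In this assay, going by these compounds alone, this position gives the first readable change: an at least 44-fold higher number from compound 1 to compound 3 (1.65 log units; beyond the scatter), toward faster clearance, with tert-butyl in place of ethoxy on an aromatic carbon between two ring nitrogen atoms. The earlier step on the triazolyl group could not be read, whereas this one shows that 2-(tert-butyl)pyrimidin-5-yl and 2-ethoxypyrimidin-5-yl are far from interchangeable on the core of compound 1. The step's size remains a floor, since its starting point is a limit and not a number: the limit of < 10 mL.min-1.g-1 in this assay, at which 2 of the 3 values shown sit.

The compounds shown do not separate the loss of the ethoxy oxygen from the entry of tert-butyl, and a methoxy, isopropyl or amine group at this position would bear on that. They also leave open whether the same step holds with 3-(trifluoromethyl)-1H-1,2,4-triazol-1-yl on the chain.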